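From bromo to nitro in a growth-inhibition series

The compounds below may be only part of what the source reports. "The series", "measured", "known", "first", "only" and "open" are said of these compounds alone.

Compound 1 `Cc1ccc(CN2CCC=C(CCC(=O)NO)C2=O)cc1`: 8100 nM
Compound 2 `COc1ccc(CN2CCC=C(CCC(=O)NO)C2=O)cc1`: 7080 nM
Compound 3 `O=C(CCC1=CCCN(Cc2ccc(Br)cc2)C1=O)NO`: 3150 nM

In a functional assay on PC-3 cells (Homo sapiens) for inhibition, read by sulforhodamine B assay (on this read-out lower numbers stand for stronger inhibition of growth and higher numbers for weaker inhibition of growth), compound 3 gives the lowest number of the three, 3150 nM. Bromo in place of methyl gave a 2.6-fold lower number from compound 1 to compound 3 (0.41 log units; beyond the scatter), and bromo in place of methoxy gave a 2.2-fold lower number from compound 2 to compound 3 (0.35 log units; beyond the scatter). Both steps are modest, while a 1.1-fold lower number from compound 1 to compound 2 (0.06 log units; within the scatter) stays within the scatter. Compound 4 `O=C(CCC1=CCCN(Cc2ccc([N+](=O)[O-])cc2)C1=O)NO` is not yet measured. It carries nitro in place of bromo on an aromatic carbon, para to a large group: nitro in place of bromo on an aromatic carbon. Among the compounds with values here, no measured step involves nitro, so the two modest steps above set the expected size. Any change is expected toward a higher number, possibly none beyond the scatter, since compound 3 at 3150 nM is the lowest so far. The expected change is a 1.4-fold higher number from compound 3 to compound 4 (0.15 log units; within the scatter). For compound 4 the estimate is 4500 nM, with an expected range of 2000 nM to 10000 nM.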

Compound 4, concentration for 50% growth inhibition: 3010 nM
For compound 4 the middle estimate is 1.5-fold (0.17 log units) above the measured one; the range from low to high includes it.
By their numbers in this assay, from the lowest: compounds 4 and 3 (each within the scatter of the next); then compounds 2 and 1 (each within the scatter of the next).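

At this place on the aromatic ring, nitro and bromo cannot be told apart: a 1.0-fold lower number from compound 3 to compound 4 (0.02 log units; within the scatter) stays within the scatter, although nitro enters with hydrogen-bond acceptors and bromo leaves with none. Nitro also stands apart from the other two groups, with a 2.4-fold lower number from compound 2 to compound 4 (0.37 log units; beyond the scatter) and a 2.7-fold lower number from compound 1 to compound 4 (0.43 log units; beyond the scatter), so that compounds 3 and 4 form a pair against compounds 1 and 2. Nothing available bears on the cause of this grouping. As far as these compounds go, whether an amine or a carboxylic acid at this place would give numbers like those of compounds 3 and 4 remains open.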